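Vinyl in place of hydroxymethyl: compound 1 to compound 3

The compounds below may be only part of what the source reports. "The series", "measured", "known", "first", "only" and "open" are said of these compounds alone.

In a functional assay on SW1573 cells (Homo sapiens) for antiproliferative activity, read by sulforhodamine B assay, with a stated time of 48 h (a higher number here means a weaker inhibitor of growth, a lower number a stronger inhibitor of growth), compound 1 (`CC(C)(C)[Si](C)(C)O[C@@H]1CCCO[C@@H]1CO`) gives > 100000 nM as a limit of the assay, not a number. In this assay compound 2 (`CC(C)(C)[Si](C)(C)O[C@@H]1CCCO[C@@H]1/C=C/C(=O)OCc1ccccc1`), which also lacks the hydroxymethyl, reads 37000 nM as a true number. Compound 3 (`C=C[C@H]1OCCC[C@H]1O[Si](C)(C)C(C)(C)C`) differs from compound 1 by vinyl in place of hydroxymethyl on a saturated ring carbon with vinyl in place of hydroxymethyl on a saturated ring carbon. For the measured compounds named here, no measured step bears directly on this change. In this assay the expected at least 1.6-fold lower number from compound 1 to compound 3 (0.22 log units; that floor lies within the scatter) is modest and toward stronger growth inhibition. For compound 3 the estimate is 60000 nM with an expected range of 25000 nM to 100000 nM in this series.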

Compound 3, concentration for 50% growth inhibition: > 100000 nM
Compound 3: only a limit was reported; the forecaster's own chance of this, stated with the estimate: 40%; middle value at least 1.6-fold (0.22 log units) from the limit.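

No step from compound 1 to compound 3 can be read in this assay, because both values are limits of the assay: the limit of > 100000 nM in this assay, at which 2 of the 3 values shown sit.

The compounds shown leave open whether vinyl in place of hydroxymethyl changes growth inhibition at all.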